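The compounds below may be only part of what the source reports. "The series", "measured", "known", "first", "only" and "open" are said of these compounds alone.

Compound 1 `CCSc1nnc(-c2cc(OC)c(OC)c(OC)c2)n1-c1ccc(OC)cc1` gives 57700 nM in a functional assay on PC-3 cells (Homo sapiens) for inhibition, read by MTT assay, with a stated time of 48 h; on this read-out lower numbers stand for stronger inhibition and higher numbers for weaker inhibition. Compound 2 `COc1ccc(-n2c(SCc3ccc(F)cc3)nnc2-c2cc(OC)c(OC)c(OC)c2)cc1` gives 35000 nM in this assay, the lowest of the two numbers shown, although a 1.6-fold lower number from compound 1 to compound 2 (0.22 log units; within the scatter) lies within the scatter. Compound 3 `COc1ccc(-n2c(SCC(=O)c3ccc(F)cc3)nnc2-c2cc(OC)c(OC)c(OC)c2)cc1` differs from compound 2 at the same place that step touched: (4-fluorophenyl)carbonyl in place of 4-fluorophenyl on a saturated chain carbon bound to a sulfur. Among the compounds with values here, the only measured step that bears on this change is a 1.6-fold lower number from compound 1 to compound 2 (0.22 log units; within the scatter), which stayed within the scatter, so no step beyond the scatter is expected in this assay. Compound 3 is therefore estimated at 30000 nM, with a range of 10000 nM to 90000 nM, which means an expected step of a 1.2-fold lower number from compound 2 to compound 3 (0.07 log units; within the scatter).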

Compound 3, half-maximal inhibitory concentration: 58300 nM
Beside the measured number, compound 3's estimate is 1.9-fold (0.29 log units) below it; the measured number falls inside the stated range.
By their numbers in this assay, from the lowest: compounds 2, 1 and 3 (each within the scatter of the next).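

At the saturated chain carbon bound to a sulfur, (4-fluorophenyl)carbonyl in place of 4-fluorophenyl gives a 1.7-fold higher number from compound 2 to compound 3 (0.22 log units; within the scatter) in this assay and, in place of methyl, gives a 1.0-fold higher number from compound 1 to compound 3 (0.00 log units; within the scatter) in the same assay. Methyl, 4-fluorophenyl and (4-fluorophenyl)carbonyl therefore all lie within the scatter of one another at this place, and the entering carbonyl, with its hydrogen-bond acceptor, brings no step beyond it. Nothing available explains this flat result.

On these data alone, whether an amine, a carboxylic acid or a longer chain at this place would bring a step beyond the scatter stays open.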